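Oxetane Attachment Point and Liver Microsome Clearance

The source may hold more compounds than are shown below. What is called first, only, known or untested is meant among the compounds shown, and "the series" means these compounds.

Measured compounds:
compound 1, `NC(=O)[C@@H](CCC(F)(F)F)N(CC1COC1)S(=O)(=O)c1ccc(Cl)cc1`, 16.9 mL/min/kg
compound 2, `NC(=O)[C@@H](CCC(F)(F)F)N(C[C@H]1CCCOC1)S(=O)(=O)c1ccc(Cl)cc1`, 156 mL/min/kg
compound 3, `NC(=O)[C@@H](CCC(F)(F)F)N(C[C@H]1CCCO1)S(=O)(=O)c1ccc(Cl)cc1`, 231 mL/min/kg

In an in vitro ADME assay on microsomes from liver (Homo sapiens) for metabolic stability, read by HPLC (on this read-out lower numbers stand for slow clearance and higher numbers for fast clearance), compound 1 stands lowest of the three: compound 2 lies a 9.2-fold higher number from compound 1 to compound 2 (0.97 log units; beyond the scatter) and compound 3 lies a 14-fold higher number from compound 1 to compound 3 (1.14 log units; beyond the scatter), while compound 2 to compound 3 is only a 1.5-fold higher number from compound 2 to compound 3 (0.17 log units; within the scatter). Compound 4, `NC(=O)[C@@H](CCC(F)(F)F)N(C[C@H]1CCO1)S(=O)(=O)c1ccc(Cl)cc1`, differs from compound 1 by oxetan-2-yl in place of oxetan-3-yl on a saturated chain carbon bound to a sulfonamide nitrogen. Both measured steps from compound 1 enlarged the ring and raised the number clearly; here the ring keeps its size and only its attachment moves. For compound 4 the expected step is therefore a 2.7-fold higher number from compound 1 to compound 4 (0.43 log units; beyond the scatter), an estimated increase that stays smaller than those measured steps. Compound 4 is estimated at 45 mL/min/kg, within 15 mL/min/kg to 140 mL/min/kg.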

Compound 4, clearance: 63.8 mL/min/kg
The estimate for compound 4 lay 1.4-fold (0.15 log units) below the measured number; low and high end bracket the measured number.
By their numbers in this assay, from the lowest: compound 1; then compound 4; then compounds 2 and 3 (each within the scatter of the next).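

In this assay the attachment point of the four-membered ring matters on its own at this position, since moving it gives a 3.8-fold higher number from compound 1 to compound 4 (0.58 log units; beyond the scatter) with the atoms unchanged. Ring size also counts with the attachment next to the ring oxygen, as oxetan-2-yl in place of oxolan-2-yl gives a 3.6-fold lower number from compound 3 to compound 4 (0.56 log units; beyond the scatter) and oxetan-2-yl in place of oxan-3-yl gives a 2.4-fold lower number from compound 2 to compound 4 (0.39 log units; beyond the scatter) and so the oxetan-2-yl compound stays between the larger rings and compound 1. No measured evidence here accounts for these differences. Open, from the compounds shown here alone, is whether a cyclobutyl or azetidin-3-yl group at this place would stay as low as compound 1, and whether the opposite stereocentre of oxetan-2-yl would read alike.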